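Ethoxy in Place of Isopropyl, Starting from a Limit

The source may report more compounds than this note shows. Statements on the series, on what has been measured and on what is new or still open speak of the compounds shown alone.

Compound 1 `Oc1cc(-c2ncc(-c3ccc(Oc4ccccc4)cc3)o2)c(Br)c(Br)c1O` and compound 2 `CC(C)c1ccc(Oc2ccc(-c3cnc(-c4cc(O)c(O)c(Br)c4Br)o3)cc2)cc1` share one core and were both tested in an assay on isolated protein for inhibition of receptor-type tyrosine-protein phosphatase F (Homo sapiens); a lower number here means a stronger inhibitor, a higher number a weaker inhibitor. For compound 1 the result is only a limit of the assay, > 40000 nM. For compound 2 the result is likewise only a limit, > 36900 nM. The step that the two limits leave unreadable from compound 1 to compound 2 therefore has no readable size, since the limit of > 36900 nM in this assay, at which 1 of the 2 values shown sits, and the limit of > 40000 nM in this assay, at which 1 of the 2 values shown sits, are both limits rather than numbers. So compound 2 stands at the edge of what this assay can report, with nothing known beyond that.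

Compound 3 `CCOc1ccc(Oc2ccc(-c3cnc(-c4cc(O)c(O)c(Br)c4Br)o3)cc2)cc1` differs from compound 2 by ethoxy in place of isopropyl on an aromatic carbon. Among the measured compounds shown here, the only measured step that bears on this change is the one from compound 1 to compound 2, and its size cannot be read, so it gives no direction. Compound 3 is therefore expected to remain at the edge of this assay, with an estimated 40000 nM between 8000 nM and 200000 nM. The step that the limit leaves unreadable from compound 2 to compound 3 implied by this estimate is expected to be none beyond the scatter.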

Compound 3, half-maximal inhibitory concentration: > 36800 nM
Compound 3 ended at the assay's limit; the forecaster's own chance of this, stated with the estimate: 85%; the middle value lies beyond the limit too.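

Among the compounds shown here, compound 1, compound 2 and compound 3 all end at limits of this assay, and no step among them can be read. Still open, as far as these compounds go, are the actual strength of each compound and whether ethoxy, isopropyl or hydrogen at this place makes any difference.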